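The source may hold more compounds than are shown below. What is called first, only, known or untested is meant among the compounds shown, and "the series" means these compounds.

Measured so far in a functional assay on a cell-free system (Platelet, plasma, Homo sapiens) for inhibition; a higher number here means a weaker inhibitor, a lower number a stronger inhibitor:
compound 1 `Cc1ccc(N(CCN2CCC(OCC(=O)O)CC2)C(=O)c2ccc(F)cc2)cc1`: 970 nM
compound 2 `Cc1ccc(N(CCN2CCC(OCC(=O)O)CC2)C(=O)c2cccc(Cl)c2)cc1`: 100 nM
compound 3 `O=C(O)COC1CCN(CCN(C(=O)c2ccc(F)cc2)c2ccc(Cl)cc2)CC1`: 2000 nM

Compound 3 has the highest number of the three, which makes it the weakest inhibitor here. Compound 4 `Cc1cccc(C(=O)N(CCN2CCC(OCC(=O)O)CC2)c2ccc(Cl)cc2)c1` differs from it in one group: 3-methylphenyl in place of 4-fluorophenyl on a carbonyl carbon. In words, 3-methylphenyl stands in place of 4-fluorophenyl on a carbonyl carbon.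

The closest measured change is a 9.7-fold lower number from compound 1 to compound 2 (0.99 log units; beyond the scatter), where 3-chlorophenyl replaced 4-fluorophenyl. The other step, a 2.1-fold higher number from compound 1 to compound 3 (0.31 log units; beyond the scatter), shows that chloro in place of methyl on an aromatic carbon also moved the number, though less. For the measured compounds named here, no measured compound carries 3-methylphenyl, so a similar but somewhat smaller drop is expected in this assay.

The expected change is a 6.7-fold lower number from compound 3 to compound 4 (0.82 log units; beyond the scatter).

For compound 4 the estimated value is 300 nM, with an expected range of 80 nM to 1100 nM.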

Compound 4, half-maximal inhibitory concentration: 310 nM
Compound 4: the middle estimate sits 1.0-fold (0.01 log units) below what was measured, and the stated range covers the measured number.
By their numbers in this assay, from the lowest: compound 2; then compound 4; then compound 1; then compound 3.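

In this assay, 3-methylphenyl in place of 4-fluorophenyl on a carbonyl carbon gives a 6.5-fold lower number from compound 3 to compound 4 (0.81 log units; beyond the scatter). The earlier drop, a 9.7-fold lower number from compound 1 to compound 2 (0.99 log units; beyond the scatter), came with 3-chlorophenyl in the methyl series, so this position also responds to a carbon-only 3-substituted ring and in a compound carrying chloro instead of methyl.

It remains open whether losing the fluorine or gaining the 3-substituent matters, since neither plain phenyl nor 4-methylphenyl is among the compounds shown. Nothing available explains the lower number.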